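Benzyl in place of phenyl on the shared core

The compounds below may be only part of what the source reports. "The series", "measured", "known", "first", "only" and "open" are said of these compounds alone.

In a functional assay on MCF7 cells (Homo sapiens) for inhibition, read by sulforhodamine B assay, with a stated time of 48 h (a lower number here means a stronger inhibitor of growth, a higher number a weaker inhibitor of growth), compound 1 (`O=C(CCl)NC(=O)Nc1cccc(OC2CCCC2)c1`) gives 6200 nM and compound 2 (`O=C(CCl)NC(=O)Nc1cccc(Oc2ccccc2)c1`) gives 8100 nM. Only these two numbers are available so far, and they cannot be told apart: the step is a 1.3-fold higher number from compound 1 to compound 2 (0.12 log units; within the scatter). Compound 2 therefore stands level with compound 1 in this assay.

The next compound, compound 3 (`O=C(CCl)NC(=O)Nc1cccc(OCc2ccccc2)c1`), keeps the shared core and changes only the group on the oxygen, with benzyl in place of phenyl on an oxygen on an aromatic ring. Going by the values given here, one measured step bears on this change, since it alters the group at the same place, with phenyl in place of cyclopentyl. That step was small, at a 1.3-fold higher number from compound 1 to compound 2 (0.12 log units; within the scatter). Among the compounds with values here, it is only a single step, and no measured compound yet carries a benzyl group, so the evidence is thin. No shift beyond the scatter is expected, and the expected step is a 1.2-fold lower number from compound 2 to compound 3 (0.06 log units; within the scatter). The estimated value for compound 3 is 7000 nM, with an expected range from 3000 nM to 16000 nM.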

Compound 3, concentration for 50% growth inhibition: 6200 nM
Compound 3: middle estimate off by 1.1-fold (0.05 log units), on the high side, and the stated range covers the measured number.
By their numbers in this assay, from the lowest: compounds 1, 3 and 2 (each within the scatter of the next).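

With benzyl, three groups on an oxygen on an aromatic ring can now be compared in this assay, and none of the pairs can be told apart: the new steps are a 1.3-fold lower number from compound 2 to compound 3 (0.12 log units; within the scatter) and no change at the digits printed from compound 1 to compound 3 (within the scatter). The phenyl-to-benzyl change takes the entering group from 6 to 7 heavy atoms while keeping one six-membered aromatic ring of carbon only, and this change leaves the reading within the scatter. The benzyl comparison with cyclopentyl also falls within the scatter, so across these three compounds the number does not separate one group from another, and no information is available to explain this result.

Going by these compounds, all three groups contain only carbon, so it remains open whether a group carrying other atoms, such as an amine or a carboxylic acid, or a longer chain such as phenethyl, would shift the number at this position beyond the scatter. The compounds shown also leave open how changes elsewhere on the shared core would compare, since all three differ only in the group on this oxygen.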